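Chloro Swap on a Benzylidene Whose Fluoro Analogue Fell Silent

The source may report more compounds than this note shows. Statements on the series, on what has been measured and on what is new or still open speak of the compounds shown alone.

Compound 2 `CC1=CC[C@H](C(C)(C)NC(=S)N/N=C/c2ccc(F)cc2)CC1` is the starting point. In a functional assay on U-251 cells (Homo sapiens) for inhibition, read by sulforhodamine B assay, with a stated time of 48 h (a lower number here means a stronger inhibitor of growth, a higher number a weaker inhibitor of growth), compound 2 gives > 100000 nM, which is a limit of the assay rather than a measured number. The closest comparison is compound 1 `CC1=CC[C@H](C(C)(C)NC(=S)N/N=C/c2ccccc2)CC1`, which carries a plain phenyl on the same carbon; in this assay compound 1 gives 26300 nM. Within the data shown here, the one measured step, fluoro in place of hydrogen on an aromatic carbon, weakened growth inhibition from compound 1 to compound 2 by an at least 3.8-fold higher number from compound 1 to compound 2 (0.58 log units; beyond the scatter), and its true size is unknown because compound 2 sits at the limit of > 100000 nM in this assay, at which 1 of the 2 values shown sits.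

Compound 3 `CC1=CC[C@H](C(C)(C)NC(=S)N/N=C/c2ccccc2Cl)CC1` differs from compound 2 by 2-chlorophenyl in place of 4-fluorophenyl on a carbon with a double bond to nitrogen. Among the measured compounds shown here, no measured step involves a chloro group or this position, so the fluoro step only hints that a halogen on this phenyl does not help. Relative to the bound for compound 2, the step from compound 2 to compound 3 is expected to be an at least 1.6-fold lower number from compound 2 to compound 3 (0.22 log units; that floor lies within the scatter). Compound 3 is therefore estimated at 60000 nM in this assay, within a wide range from 15000 nM to 200000 nM, with a real chance that only a limit is reported again.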

Compound 3, concentration for 50% growth inhibition: 80600 nM
Compound 3: the middle estimate sits 1.3-fold (0.13 log units) below what was measured, and the stated range covers the measured number.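

In this assay compound 3 gives 80600 nM, a measured number, so a halogen on this phenyl does not always take the value out of the assay's readable range. Adding a chlorine to the phenyl gives a 3.1-fold higher number from compound 1 to compound 3 (0.49 log units; beyond the scatter), which puts a real size on a loss of growth inhibition relative to the plain phenyl, and both halogen compounds shown, compound 2 and compound 3, now point the same way with none going against it. The swap of 4-fluorophenyl for 2-chlorophenyl gives an at least 1.2-fold lower number from compound 2 to compound 3 (0.09 log units; that floor lies within the scatter), a floor within the scatter, and compound 2 carries only a limit, so whether this swap truly improves growth inhibition cannot be read: the limit of > 100000 nM in this assay, at which 1 of the 3 values shown sits.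

Compound 2 and compound 3 differ both in the halogen and in where it sits on the phenyl, so the two effects remain tangled, and a 4-chlorophenyl would help to separate them. Also open, going by these compounds, is whether a group of a different kind on this phenyl, such as a hydroxy group or an amine, could bring the number below that of compound 1 rather than above it.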